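A Carboxyphenylsulfonyl Group Replaces the Pyridyl Carbonyl

The source may hold more compounds than are shown below. What is called first, only, known or untested is meant among the compounds shown, and "the series" means these compounds.

Measured so far:
compound 1 `O=C(c1ccc(C(F)(F)F)cc1)N1CCC(NS(=O)(=O)c2cc(S(=O)(=O)c3ccccc3)ccc2C(F)(F)F)CC1`, 970 nM
compound 2 `O=C(c1ccccn1)N1CCC(NS(=O)(=O)c2cc(S(=O)(=O)c3ccccc3)ccc2C(F)(F)F)CC1`, 230 nM
compound 3 `CN(C)c1ccc(C(=O)N2CCC(NS(=O)(=O)c3cc(S(=O)(=O)c4ccccc4)ccc3C(F)(F)F)CC2)cn1`, 70 nM

In an assay on U2OS cells for inhibition of secreted frizzled-related protein 1 (Homo sapiens), read by a luciferase reporter, with a stated time of 18 h (on this read-out lower numbers stand for an effect already at smaller amounts and higher numbers for an effect only at larger amounts of compound), compound 3 gives the lowest number of the three, with compound 2 nearest and compound 1 furthest, as the steps of a 3.3-fold lower number from compound 2 to compound 3 (0.52 log units; beyond the scatter) and a 14-fold lower number from compound 1 to compound 3 (1.14 log units; beyond the scatter) show. Compound 4 `O=C(O)c1ccc(S(=O)(=O)N2CCC(NS(=O)(=O)c3cc(S(=O)(=O)c4ccccc4)ccc3C(F)(F)F)CC2)cc1` differs from compound 3 by (4-carboxyphenyl)sulfonyl in place of (6-(dimethylamino)pyridin-3-yl)carbonyl on an amine nitrogen in a ring. Among the compounds with values here, none of the measured steps bears directly on this change; all three vary only the aryl group on the carbonyl, and each step away from the group in compound 3 raised the number, by a 3.3-fold lower number from compound 2 to compound 3 (0.52 log units; beyond the scatter) and a 14-fold lower number from compound 1 to compound 3 (1.14 log units; beyond the scatter) read in reverse. Removing that group entirely is therefore expected to give a higher number, with a 21-fold higher number from compound 3 to compound 4 (1.33 log units; beyond the scatter). Compound 4 is estimated at 1500 nM, within 300 nM to 8000 nM.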

Compound 4, half-maximal effective concentration: 110 nM
Compound 4: the middle estimate sits 14-fold (1.13 log units) above what was measured, and the stated range ends above it.
By their numbers in this assay, from the lowest: compounds 3 and 4 (each within the scatter of the next); then compound 2; then compound 1.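

At this amine nitrogen in a ring, (4-carboxyphenyl)sulfonyl can replace (6-(dimethylamino)pyridin-3-yl)carbonyl with a 1.6-fold higher number from compound 3 to compound 4 (0.20 log units; within the scatter) and thus shows that an aryl carbonyl is not required there. The same group also compares well with the other two carbonyl groups, giving a 2.1-fold lower number from compound 2 to compound 4 (0.32 log units; beyond the scatter) and an 8.8-fold lower number from compound 1 to compound 4 (0.95 log units; beyond the scatter) in turn. No available evidence accounts for this result.

As far as these compounds go, the carboxylic acid and the sulfonyl linkage change together here, so their separate contributions remain open. A methyl ester or an unsubstituted phenylsulfonyl group on the same nitrogen would separate them.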